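A few compounds are considered here, and "the series" means these few. Any claim that something is new, unique, unknown or untested is made for them only; others in the source may bear on it.

Two closely related compounds have so far been measured in a functional assay on NCI-H522 cells (Homo sapiens) for antiproliferative activity, read by sulforhodamine B assay, with a stated time of 48 h; a higher number here means a weaker inhibitor of growth, a lower number a stronger inhibitor of growth. Compound 1 `Cc1nc(SCC(=O)Nc2nc(-c3ccc(Cl)cc3)cs2)n(Nc2ccccc2)c1C` gives 2540 nM in this assay. Compound 2 `Cc1ccc(Nn2c(SCC(=O)Nc3nc(-c4ccccc4)cs3)nc(C)c2C)cc1` differs from compound 1 in more than one place; in this assay compound 2 gives 2970 nM, and the two numbers lie within the usual scatter of each other, so neither compound can be called the stronger or weaker inhibitor of growth on this evidence.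

The next compound, compound 3 `COc1ccc(Nn2c(SCC(=O)Nc3nc(-c4ccc(Cl)cc4)cs3)nc(C)c2C)cc1`, has not yet been measured. Compared with compound 1, the change is methoxy in place of hydrogen on an aromatic carbon. Among the compounds with values here, no pair of measured compounds that differ in only one place is available, so the size of such a step cannot be read off from a measured example. Within the data shown here, the only guidance is that compound 2 gives 2970 nM, a number close to that of compound 1, although its differences are not the same change. On that basis the expected step of a 1.0-fold higher number from compound 1 to compound 3 (0.01 log units; within the scatter) is small, with no clear direction beyond the scatter. Compound 3 is therefore estimated to give 2600 nM in this assay, with a plausible range from 1200 nM to 5600 nM.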

Compound 3, concentration for 50% growth inhibition: 5050 nM
The estimate for compound 3 lay 1.9-fold (0.29 log units) below the measured number, within the range that was stated.
By their numbers in this assay, from the lowest: compounds 1, 2 and 3 (each within the scatter of the next).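

Within the data shown here, compound 1 and compound 3 give the first measured step that differs in one place only. It puts methoxy in place of hydrogen on an aromatic carbon of the six-membered aromatic ring of carbon only, para to a large group. In this assay the step is a 2.0-fold higher number from compound 1 to compound 3 (0.30 log units; within the scatter), so this change cannot be told apart from repeat-to-repeat variation, and adding methoxy at this position shows no clear gain or loss in growth inhibition. No measurement bears on why the step has this size.

On these data alone, a single substituent cannot show how much this position responds to other groups, so it remains open whether an amine, a carboxylic acid or a longer chain such as butoxy in the same place would give a step beyond the scatter. Also open, as far as these compounds go, is what each separate difference between compound 1 and compound 2 contributes, since those two compounds differ in more than one place.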